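A chloro added to a weak growth inhibitor

The source may hold more compounds than are shown below. What is called first, only, known or untested is meant among the compounds shown, and "the series" means these compounds.

Measured compounds:
compound 1, `Cc1cc(S(=O)(=O)Nc2nc3cscc3c(=O)n2Cc2ccccc2)c(S)cc1Cl`, 18900 nM
compound 2, `Cc1cc(S(=O)(=O)Nc2nc3cc(-c4ccccc4)sc3c(=O)n2Cc2ccccc2)c(S)cc1Cl`, > 100000 nM

In a functional assay on HCC 2998 cells (Homo sapiens) for inhibition (a lower number here means a stronger inhibitor of growth, a higher number a weaker inhibitor of growth), compound 1 gives 18900 nM. For compound 2 the this assay reports only a limit, > 100000 nM. Compound 2 thus stands at the edge of the numbers shown, as the limit of > 100000 nM in this assay, at which 1 of the 2 values shown sits, records. Compound 3, `Cc1cc(S(=O)(=O)Nc2nc3cc(-c4ccc(Cl)cc4)sc3c(=O)n2Cc2ccccc2)c(S)cc1Cl`, differs from compound 2 by chloro in place of hydrogen on an aromatic carbon. Among the compounds with values here, no measured pair shows what this change does, so a step of a number no higher from compound 2 to compound 3 (the limit leaves the size open) is expected, within the scatter, and most likely again only a limit. Compound 3 is therefore estimated at 100000 nM, between 30000 nM and 300000 nM.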

Compound 3, concentration for 50% growth inhibition: > 100000 nM
Compound 3 gave a limit, no number; the forecaster's own chance of this, stated with the estimate: 70%; the middle value sits exactly at the limit.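

Within the data shown here, compound 2 and compound 3 each give only a limit in this assay, so no step between them can be read: the limit of > 100000 nM in this assay, at which 2 of the 3 values shown sit. The compounds shown leave open what the change from phenyl to 4-chlorophenyl does to growth inhibition.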